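The source may report more compounds than this note shows. Statements on the series, on what has been measured and on what is new or still open speak of the compounds shown alone.

Measured compounds in a functional assay on MCF7 cells (Homo sapiens) for cytotoxicity, read by MTT assay; a higher number here means a weaker inhibitor, a lower number a stronger inhibitor:

Compound 1, `COc1cc(/C=C2\CCC/C(=C\c3cccc([N+](=O)[O-])c3)C2=O)cc(Br)c1OC`, gives 4.72 ug/mL.
Compound 2, `CCOc1c(Br)cc(/C=C2\CCC/C(=C\c3cccc([N+](=O)[O-])c3)C2=O)cc1OC`, gives 24.9 ug/mL.
Compound 3, `COc1cc(/C=C2\CCC/C(=C\c3ccc([N+](=O)[O-])cc3)C2=O)cc(Br)c1OC`, gives 11 ug/mL.

Two changes run through this set. The first is methyl in place of hydrogen on a saturated chain carbon bound to an oxygen on an aromatic ring. It carries a step of a 5.3-fold higher number from compound 1 to compound 2 (0.72 log units; beyond the scatter), which lies beyond the scatter, so in this assay the ethoxy compound is the weaker of the pair. The second is the difference between the two cores, (4-nitrophenyl in place of 3-nitrophenyl on a double-bonded chain carbon bound to a double-bonded ring carbon); here the step is a 2.3-fold higher number from compound 1 to compound 3 (0.37 log units; beyond the scatter), also beyond the scatter, so the 4-nitrophenyl core starts from a weaker position than the 3-nitrophenyl core.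

Compound 4, `CCOc1c(Br)cc(/C=C2\CCC/C(=C\c3ccc([N+](=O)[O-])cc3)C2=O)cc1OC`, has not yet been measured in this assay. It differs from compound 3 by methyl in place of hydrogen on a saturated chain carbon bound to an oxygen on an aromatic ring. This is the same change as that from compound 1 to compound 2, made on the other core; the place of the change is worded identically in both cases. On that basis the step is expected to be similar in direction and size, that is, compound 4 is expected to be weaker than compound 3 by about a 4.1-fold higher number from compound 3 to compound 4 (0.61 log units; beyond the scatter), because the same change produced a 5.3-fold higher number from compound 1 to compound 2 (0.72 log units; beyond the scatter). The expectation rests on a single earlier instance, so the size is uncertain; the direction is the more confident part.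

Compound 4 is therefore estimated at 45 ug/mL in this assay, with a range from 20 ug/mL to 110 ug/mL.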

Compound 4, half-maximal inhibitory concentration: 3.08 ug/mL
Compound 4: the middle estimate sits 15-fold (1.16 log units) above what was measured; the measured number lies below the stated range.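

In this assay, methoxy to ethoxy does not carry from one core to the other: with the 3-nitrophenyl group the change weakens the compound, whereas with the 4-nitrophenyl group it gives a 3.6-fold lower number from compound 3 to compound 4 (0.55 log units; beyond the scatter), so both size and direction depend on the core: the same change on two cores in this assay, a 5.3-fold higher number (0.72 log units; beyond the scatter) from compound 1 to compound 2 and a 3.6-fold lower number (0.55 log units; beyond the scatter) from compound 3 to compound 4, 19-fold (1.28 log units) apart, beyond the scatter of two such steps

The same dependence appears when the four compounds are read the other way, since 4-nitrophenyl in place of 3-nitrophenyl gives an 8.1-fold lower number from compound 2 to compound 4 (0.91 log units; beyond the scatter) among the ethoxy compounds, the opposite direction to the step among the methoxy compounds: the same change on two cores in this assay, a 2.3-fold higher number (0.37 log units; beyond the scatter) from compound 1 to compound 3 and an 8.1-fold lower number (0.91 log units; beyond the scatter) from compound 2 to compound 4, 19-fold (1.28 log units) apart, beyond the scatter of two such steps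

These two comparisons come from the same four compounds and are one interaction seen from two sides, not independent findings, and with a single pair for each change they do not show which step is typical of the series or what underlies the reversal.

On these data alone, it remains open whether a longer chain, such as propoxy or butoxy, would continue the trend seen on either core. As far as these compounds go, it is also open whether the reversal survives when the nitro group is replaced by an amine or a carboxylic acid.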